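Cytotoxicity notes: substituent swap on the aryl amide

The compounds below may be only part of what the source reports. "The series", "measured", "known", "first", "only" and "open" are said of these compounds alone.

Among the compounds with values here, compound 2 `Cc1nc(-c2cccc(C(=O)N3CCCC(C(=O)Nc4ccc(Cl)cc4)C3)c2)cs1` gives 1% in an ADME assay on PC-3 cells (Homo sapiens) for cytotoxicity, read by WST assay, tested at 100 uM (a lower number here means less inhibition, a higher number more inhibition at the concentration tested (going by the name of the read-out)), the highest of the two numbers measured so far; its nearest neighbour, compound 1 `COCc1cccc(C(=O)N2CCCC(C(=O)Nc3ccc(Cl)cc3)C2)c1`, gives 0% in this assay, within the scatter. Compound 3 `CCN(CC)S(=O)(=O)c1cccc(C(=O)N2CCCC(C(=O)Nc3ccc(Cl)cc3)C2)c1` differs from compound 2 by one change: diethylsulfamoyl in place of 2-methyl-1,3-thiazol-4-yl on an aromatic carbon. Within the data shown here, the one measured step that bears on this change, a number 1 percentage points higher from compound 1 to compound 2 (within the scatter), was within the scatter, and both measured values sit at the floor of the read-out. No step beyond the scatter is expected, a number 1 percentage points higher from compound 2 to compound 3 (within the scatter). The estimate for compound 3 in this assay is 2%, ranging from 0% to 12%.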

Compound 3, a percentage reported as inhibition, at one concentration (the size of the read-out at that concentration, not a potency): 0%
Compound 3: the middle estimate sits 2 percentage points above what was measured, and the stated range covers the measured number.
By their numbers in this assay, from the lowest: compounds 1, 3 and 2 (each within the scatter of the next).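

Diethylsulfamoyl on this aromatic carbon, meta to a large group, gives a number 1 percentage points lower from compound 2 to compound 3 (within the scatter) and no change at the digits printed from compound 1 to compound 3 (within the scatter) in this assay. A substituent with no ring and two double bonds outside aromatic rings therefore reads the same here as the 2-methyl-1,3-thiazol-4-yl and methoxymethyl groups, so this position shows no response across the three compounds. Nothing at hand gives a reason for this flat result.

From the compounds shown here alone, whether a primary amine or a carboxylic acid on this carbon would move the read-out stays open. So does whether replacing the chlorine elsewhere on the core would do so.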